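Chloro substitution and tolerated concentration in a three-compound series

The source may report more compounds than this note shows. Statements on the series, on what has been measured and on what is new or still open speak of the compounds shown alone.

Compound 1 `O=C(NOCc1ccccc1F)c1cn(-c2ccccc2)nc1-c1ccccc1` gives 75700 nM in an ADME assay on HEK-293T cells (Homo sapiens) for antiproliferative activity, read by MTT assay, with a stated time of 48 h, in the presence of a further agent that is not named here; a higher number here means that more compound is tolerated, a lower number that less compound is tolerated. Compound 2 `O=C(NOCc1ccccc1F)c1cn(-c2ccccc2)nc1-c1ccc(Cl)cc1` carries chloro in place of hydrogen on an aromatic carbon and gives 126000 nM in this assay, so that the step of a 1.7-fold higher number from compound 1 to compound 2 (0.22 log units; within the scatter) is recorded. Compound 3 `O=C(NOCc1ccccc1Cl)c1cn(-c2ccccc2)nc1-c1ccc(Cl)cc1` gives 129000 nM in this assay, with the step of a 1.0-fold higher number from compound 2 to compound 3 (0.01 log units; within the scatter). The difference between the cores of compound 1 and compound 3 is not broken down here. Compound 4 `O=C(NOCc1ccc(Cl)cc1Cl)c1cn(-c2ccccc2)nc1-c1ccc(Cl)cc1` has not yet been measured in this assay; it carries chloro in place of hydrogen on an aromatic carbon. For the measured compounds named here, this is the same kind of change as the one from compound 1 to compound 2, but not the same: there the entering chloro sits para to a large group, here it sits meta to a chloro group and para to a large group. For compound 4 the expected step is a 1.1-fold lower number from compound 3 to compound 4 (0.03 log units; within the scatter). That expectation rests on the size of a 1.7-fold higher number from compound 1 to compound 2 (0.22 log units; within the scatter), which stayed within the scatter. Compound 4 is therefore expected to give 120000 nM in this assay, estimated to lie between 60000 nM and 240000 nM.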

Compound 4, half-maximal cytotoxic concentration: 46300 nM
The estimate for compound 4 lay 2.6-fold (0.41 log units) above the measured number; the whole stated range lies above it.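

In this assay, chloro in place of hydrogen on an aromatic carbon does not carry over as a fixed step from one core to another in this series: the same change on two cores in this assay, a 1.7-fold higher number (0.22 log units; within the scatter) from compound 1 to compound 2 and a 2.8-fold lower number (0.45 log units; beyond the scatter) from compound 3 to compound 4, 4.6-fold (0.67 log units) apart, beyond the scatter of two such steps The step of a 2.8-fold lower number from compound 3 to compound 4 (0.45 log units; beyond the scatter) is modest, and the wider change of 2,4-dichlorophenyl in place of 2-fluorophenyl gives a similar a 2.7-fold lower number from compound 2 to compound 4 (0.43 log units; beyond the scatter). This does not show what sets the two chloro steps apart, since they differ in both the core and the surroundings of the entering chloro, which in compound 4 sits meta to a chloro group and para to a large group.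

On these data alone, it remains open whether the 2,4-dichlorobenzyl group would give a lower number on the core of compound 1 as well. As far as these compounds go, it is equally open whether a methoxy group or an amine at the same place on the ring would follow chloro or would leave the number within the scatter of compound 3.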